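A few compounds are considered here, and "the series" means these few. Any claim that something is new, unique, unknown or untested is made for them only; others in the source may bear on it.

Of the compounds shown here, three have so far been measured in an assay on IM-9 cells for binding affinity to Substance-P receptor (Homo sapiens); a lower number here means a stronger inhibitor, a higher number a weaker inhibitor. Compound 1 `COc1ccccc1CN(C)C(=O)Nc1c(-c2ccccc2)c2cc(C)c(C)cc2c(=O)n1C` gives 23 nM. Compound 2 `CN(Cc1cc(C(F)(F)F)cc(C(F)(F)F)c1)C(=O)c1c(-c2ccccc2)c2cccnc2c(=O)n1C` gives 0.25 nM, and compound 3 `CN(Cc1cc(C(F)(F)F)cc(C(F)(F)F)c1)Cc1c(-c2ccccc2)c2ccccc2c(=O)n1C` gives 600 nM. Among these three numbers compound 1 holds the second highest: its nearest neighbour is compound 3, whose number lies well above it, and the furthest is compound 2, whose number lies far below it. Neither of those pairs differs in just one place, so they show only how wide the spread across this small set is.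

Compound 4 `CCN(Cc1ccccc1)C(=O)Nc1c(-c2ccccc2)c2cc(C)c(C)cc2c(=O)n1C` has not yet been measured. It shares the core of compound 1 and differs from it in a single place: benzyl(ethyl)amino in place of (2-methoxybenzyl)(methyl)amino on a carbonyl carbon. Within the data shown here, both the group on the aromatic ring and the short chain on the nitrogen change at once, and no measured pair shows what either change does on this core. The expected step in this assay is a 2.2-fold higher number from compound 1 to compound 4 (0.34 log units; beyond the scatter), a modest move toward a higher number that may stay within the scatter. Compound 4 is therefore estimated at 50 nM, with a likely range from 10 nM to 250 nM.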

Compound 4, half-maximal inhibitory concentration: 66 nM
Compound 4: the middle estimate sits 1.3-fold (0.12 log units) below what was measured; measured number inside the range.
By their numbers in this assay, from the lowest: compound 2; then compound 1; then compound 4; then compound 3.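

Among these compounds, this is the first comparison here in which only one place differs. In this assay, benzyl(ethyl)amino in place of (2-methoxybenzyl)(methyl)amino on the carbonyl carbon gives a 2.9-fold higher number from compound 1 to compound 4 (0.46 log units; beyond the scatter), so this place does affect the read-out, although this particular change moves the number only modestly. Nothing available explains why the number moves in this direction.

The compounds shown leave open whether the step comes from losing the methoxy group on the aromatic ring, from replacing the methyl on the nitrogen with an ethyl, or from both together. Benzyl(methyl)amino at this same place would help separate those two changes, and a propyl chain on the nitrogen would show how the number responds as that chain grows longer.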